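The source may hold more compounds than are shown below. What is called first, only, known or untested is meant among the compounds shown, and "the series" means these compounds.

Measured in a functional assay on A549 cells (Homo sapiens) for cytotoxicity, read by WST assay, with a stated time of 48 h; a lower number here means a stronger inhibitor, a higher number a weaker inhibitor:
compound 1, `COc1ccc2c(/C=C(\C#N)C(=O)c3c[nH]c4cc(F)ccc34)c[nH]c2c1`, gives 5500 nM
compound 2, `COc1ccc2[nH]cc(/C=C(\C#N)C(=O)c3c[nH]c4ccccc34)c2c1`, gives 13700 nM
compound 3, `COc1ccc2c(/C=C(\C#N)C(=O)c3c[nH]c4ccccc34)c[nH]c2c1`, gives 5800 nM

Compound 4, `COc1ccc2[nH]cc(/C=C(\C#N)C(=O)c3c[nH]c4cc(F)ccc34)c2c1`, has not yet been measured in this assay. Compounds 2 and 3 are built from the same atoms joined differently; the difference between the two cores is not broken down here. Of the three measured compounds, compound 2 gives the highest number, while compound 1 and compound 3 lie within the scatter of each other.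

The change from compound 3 to compound 1 is fluoro in place of hydrogen on an aromatic carbon, and it gave a 1.1-fold lower number from compound 3 to compound 1 (0.02 log units; within the scatter). The same change, (fluoro in place of hydrogen on an aromatic carbon), leads from compound 2 to compound 4, at a place described in the same words. Because the earlier step of a 1.1-fold lower number from compound 3 to compound 1 (0.02 log units; within the scatter) was within the scatter, compound 4 is expected to stay close to compound 2, with an expected step of a 1.1-fold lower number from compound 2 to compound 4 (0.04 log units; within the scatter). Compound 4 is therefore estimated at 12500 nM in this assay, expected between 6000 nM and 26000 nM.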

Compound 4, half-maximal inhibitory concentration: 26300 nM
For compound 4 the middle estimate is 2.1-fold (0.32 log units) below the measured one; measured number outside the range, above it.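

In this assay fluoro in place of hydrogen on an aromatic carbon gave a 1.9-fold higher number from compound 2 to compound 4 (0.28 log units; within the scatter) and so stayed within the usual scatter on this core as well. Set beside the earlier step, the change shows no difference between the two cores that exceeds what two such steps can scatter: the same change on two cores in this assay, a 1.1-fold lower number (0.02 log units; within the scatter) from compound 3 to compound 1 and a 1.9-fold higher number (0.28 log units; within the scatter) from compound 2 to compound 4, 2.0-fold (0.31 log units) apart, within the scatter of two such steps
For the compounds shown here, in both pairs, then, the change carried from one core to the other without a step beyond the scatter, but this does not show that fluoro is without effect or that the two cores respond alike, as a small real difference could lie hidden in the scatter and only one pair stands for each core.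

The compounds shown leave open whether a different group at this place, such as chloro or an amine, would move the number beyond the scatter on either core. They also leave open what would happen if the nitrile gave way to an amide or a carboxylic acid.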